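Rat plasma half-life: moving the methyl on the benzoyl ring

The compounds below may be only part of what the source reports. "The series", "measured", "known", "first", "only" and "open" are said of these compounds alone.

Measured compounds in an ADME assay on a cell-free system (plasma, Homo sapiens) for metabolic stability, with Plasma (Rattus norvegicus) as the target, read by HPLC, at pH 7.4; on this read-out lower numbers stand for a shorter-lived compound and higher numbers for a longer-lived compound:
Compound 1 `CC(=O)Oc1ccccc1C(=O)O[C@H]1CO[C@H]2[C@@H]1OC[C@H]2OC(=O)c1snnc1C` gives 0.0065 h.
Compound 2 `CCCCC(=O)O[C@@H]1CO[C@H]2[C@@H]1OC[C@@H]2OC(=O)c1ccccc1OC(C)=O` gives 0.0117 h.
Compound 3 `CC(=O)Oc1ccccc1C(=O)O[C@H]1CO[C@H]2[C@@H]1OC[C@H]2OC(=O)c1ccccc1C` gives 0.0138 h.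

Compound 3 gives the highest of the three numbers, but only its distance from compound 1 is beyond the scatter: a 2.1-fold higher number from compound 1 to compound 3 (0.33 log units; beyond the scatter) is modest, while a 1.2-fold higher number from compound 2 to compound 3 (0.07 log units; within the scatter) is within the scatter, as is a 1.8-fold higher number from compound 1 to compound 2 (0.26 log units; within the scatter). All three steps exchange the group on one carbonyl carbon, and the spread across them is small.

Compound 4 `CC(=O)Oc1ccccc1C(=O)O[C@H]1CO[C@H]2[C@@H]1OC[C@H]2OC(=O)c1cccc(C)c1` is the next step from compound 3: 3-methylphenyl in place of 2-methylphenyl on a carbonyl carbon. Going by the values given here, no measured pair changes only the position of a methyl on the aromatic ring, so nothing bears on this change directly. The three steps that do exist show that replacing the whole group on that carbonyl carbon shifts the half-life in this assay by at most a modest amount, and a shift of the methyl within the same ring is a smaller change than any of them. No step beyond the scatter is therefore expected, and the estimated step is a 1.0-fold higher number from compound 3 to compound 4 (0.01 log units; within the scatter). For compound 4 the expected half-life in this assay is 0.014 h, with a range of 0.007 h to 0.028 h.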

Compound 4, half-life: 0.0203 h
For compound 4 the middle estimate is 1.5-fold (0.16 log units) below the measured one; the measured number falls inside the stated range.
By their numbers in this assay, from the lowest: compounds 1, 2, 3 and 4 (each within the scatter of the next, the first and the last beyond it).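

Moving the methyl on this carbonyl carbon's ring now has a direct reading in this assay: 3-methylphenyl in place of 2-methylphenyl gives a 1.5-fold higher number from compound 3 to compound 4 (0.17 log units; within the scatter), so this pair of ring positions is not separated here. Compared with butyl, 3-methylphenyl gives a 1.7-fold higher number from compound 2 to compound 4 (0.24 log units; within the scatter), and compared with 4-methyl-1,2,3-thiadiazol-5-yl it gives a 3.1-fold higher number from compound 1 to compound 4 (0.49 log units; beyond the scatter), which places both methylphenyl groups beyond the scatter from compound 1 only. No supporting data bear on the reason for these half-lives.

As far as these compounds go, how 4-methylphenyl, unsubstituted phenyl or a chain longer than butyl would read on this carbonyl carbon remains open. Also open, from the compounds shown here alone, is whether the methyl move reads the same when the other ester on the shared core is changed.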